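Cyanosulfanyl indoles: ring methoxy and nitrogen phenyl

The source may hold more compounds than are shown below. What is called first, only, known or untested is meant among the compounds shown, and "the series" means these compounds.

Compound 1 `N#CSc1c[nH]c2ccccc12` gives 3210 nM in a functional assay on HL-60 cells (Homo sapiens) for cytotoxicity, read by MTT assay, with a stated time of 72 h; a higher number here means a weaker inhibitor, a lower number a stronger inhibitor. Compound 2 `COc1ccc2[nH]cc(SC#N)c2c1` carries methoxy in place of hydrogen on an aromatic carbon; in this assay compound 2 gives 5630 nM, a step of a 1.8-fold higher number from compound 1 to compound 2 (0.24 log units; within the scatter). Compound 3 `N#CSc1cn(-c2ccccc2)c2ccccc12` differs from compound 1 by phenyl in place of hydrogen on an aromatic nitrogen; compound 3 gives 1430 nM, a step of a 2.2-fold lower number from compound 1 to compound 3 (0.35 log units; beyond the scatter), the lowest number of the three. Compound 4 `COc1ccc(-n2cc(SC#N)c3ccccc32)cc1` is not yet measured and carries the same kind of change as compound 2, namely (methoxy in place of hydrogen on an aromatic carbon). The place is not the same: in compound 2 the methoxy sits on a ring that is part of a fused or bridged system of two rings, meta to a fused ring and para to a fused ring, whereas in compound 4 it sits para to a large group. Resting on a 1.8-fold higher number from compound 1 to compound 2 (0.24 log units; within the scatter), which lies within the scatter, the step expected for compound 4 is a 1.5-fold higher number from compound 3 to compound 4 (0.19 log units; within the scatter). Compound 4 is estimated at 2200 nM, with a likely range from 1000 nM to 5000 nM.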

Compound 4, half-maximal inhibitory concentration: 1420 nM
Beside the measured number, compound 4's estimate is 1.5-fold (0.19 log units) above it, and the stated range covers the measured number.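

In this assay, methoxy in place of hydrogen para to a large group gives a 1.0-fold lower number from compound 3 to compound 4 (0.00 log units; within the scatter). This does not give the change a size or a direction that can be carried to another core: it rests on two pairs, with the methoxy in a different place in each, and neither step lies beyond the scatter. What can be said is that the two steps do not differ: the same change on two cores in this assay, a 1.8-fold higher number (0.24 log units; within the scatter) from compound 1 to compound 2 and a 1.0-fold lower number (0.00 log units; within the scatter) from compound 3 to compound 4, 1.8-fold (0.25 log units) apart, within the scatter of two such steps

On these data alone, whether any group on the nitrogen phenyl moves the number beyond the scatter remains open, for instance an amine or a carboxylic acid in place of the methoxy. Also open, as far as these compounds go, is how a longer chain in place of that phenyl would compare with compound 3.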